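Triazolyl chalcones: hydroxyl-to-alkene step on the triazole

The source may hold more compounds than are shown below. What is called first, only, known or untested is meant among the compounds shown, and "the series" means these compounds.

Measured so far:
compound 1 `COc1cc(/C=C/C(=O)c2cccc(-n3cc(C(C)(C)O)nn3)c2)ccc1O` 19800 nM
compound 2 `C=C(C)c1cn(-c2cccc(C(=O)/C=C/c3ccc(O)c(OC)c3)c2)nn1` 9790 nM
compound 3 `COc1ccc(/C=C/C(=O)c2cccc(-n3cc(C(C)(C)O)nn3)c2)cc1O` 17100 nM

All three were read in a functional assay on RAW264.7 cells (Mus musculus) for inhibition, with a stated time of 4 days; a higher number here means a weaker inhibitor, a lower number a stronger inhibitor. Compound 1 and compound 3 share everything but the arrangement of the phenol: 3-hydroxy-4-methoxyphenyl in place of 4-hydroxy-3-methoxyphenyl on a double-bonded chain carbon bound to a double-bonded chain carbon, and the step of a 1.2-fold lower number from compound 1 to compound 3 (0.06 log units; within the scatter) leaves the two within the usual scatter. Compound 2 differs from compound 1 by 1-methylethenyl in place of 1-hydroxy-1-methylethyl on an aromatic carbon; that step, a 2.0-fold lower number from compound 1 to compound 2 (0.31 log units; beyond the scatter), is modest but beyond the scatter.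

Compound 4 `C=C(C)c1cn(-c2cccc(C(=O)/C=C/c3ccc(OC)c(O)c3)c2)nn1` is not yet measured. It stands to compound 3 as compound 2 stands to compound 1: 1-methylethenyl in place of 1-hydroxy-1-methylethyl on an aromatic carbon, the same change at the same place. Since compound 3 and compound 1 sit together, a step of about the same size is expected, a 2.0-fold lower number from compound 3 to compound 4 (0.30 log units; within the scatter), resting on compound 1 to compound 2 a 2.0-fold lower number from compound 1 to compound 2 (0.31 log units; beyond the scatter). Compound 4 is therefore estimated at 8600 nM in this assay, expected between 4500 nM and 16500 nM.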

Compound 4, half-maximal inhibitory concentration: 7760 nM
The estimate for compound 4 lay 1.1-fold (0.04 log units) above the measured number; the measured number falls inside the stated range.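

In this assay, 1-methylethenyl in place of 1-hydroxy-1-methylethyl gives a 2.2-fold lower number from compound 3 to compound 4 (0.34 log units; beyond the scatter), and this step carries over between the two phenol arrangements: the same change on two cores in this assay, a 2.0-fold lower number (0.31 log units; beyond the scatter) from compound 1 to compound 2 and a 2.2-fold lower number (0.34 log units; beyond the scatter) from compound 3 to compound 4, 1.1-fold (0.04 log units) apart, within the scatter of two such steps. The exchange of the phenol arrangement remains within the scatter on the 1-methylethenyl compounds, with a 1.3-fold lower number from compound 2 to compound 4 (0.10 log units; within the scatter), and it matches its counterpart: the same change on two cores in this assay, a 1.2-fold lower number (0.06 log units; within the scatter) from compound 1 to compound 3 and a 1.3-fold lower number (0.10 log units; within the scatter) from compound 2 to compound 4, 1.1-fold (0.04 log units) apart, within the scatter of two such steps. This shows transfer only between two closely related cores, and it does not show that the step would hold on a core that differs elsewhere.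

Still open, on these data alone, is how other groups at this aromatic carbon would compare, such as an amine, a carboxylic acid or a longer alkyl chain. Also open, as far as these compounds go, is whether the step persists with an ethoxy group in place of the methoxy.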